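This account rests on a few compounds, and the source may have more. Where it says the series, first, only, none or still open, it means among the compounds named here.

Compound 1 `C=CCn1c(=O)/c(=C\c2cccc(F)c2)[nH]c(=O)/c1=C\c1ccccc1OC` gives 5600 nM in a functional assay on BGC-823 cells (Homo sapiens) for cytotoxicity, read by CCK-8 assay, with a stated time of 72 h (a higher number here means a weaker inhibitor, a lower number a stronger inhibitor), the second highest of the three numbers measured. Compound 2 `C=CCn1c(=O)/c(=C\c2cccc(Cl)c2Cl)[nH]c(=O)/c1=C\c1ccccc1OC` gives 2200 nM, a step of a 2.5-fold lower number from compound 1 to compound 2 (0.41 log units; beyond the scatter). Compound 3 `C=CCn1c(=O)/c(=C\c2ccccc2OC)[nH]c(=O)/c1=C\c1ccccc1OC` gives 13400 nM, a step of a 2.4-fold higher number from compound 1 to compound 3 (0.38 log units; beyond the scatter), and between the two outer compounds the step is a 6.1-fold higher number from compound 2 to compound 3 (0.78 log units; beyond the scatter).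

Compound 4 `C=CCn1c(=O)/c(=C\c2cccc(C)c2)[nH]c(=O)/c1=C\c1ccccc1OC` is the next step from compound 1, with a single difference: methyl in place of fluoro on an aromatic carbon. Going by the values given here, none of the measured steps bears directly on this change; each of them exchanges the whole substituent on the double-bonded chain carbon for a different one, and even those larger exchanges moved this assay only modestly. A swap of one heavy atom for another of the same size, with nothing gained or lost in donors or acceptors, is therefore expected to give a step of a 1.1-fold lower number from compound 1 to compound 4 (0.05 log units; within the scatter), not beyond the scatter. Compound 4 is expected at 5000 nM, within 2000 nM to 13000 nM.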

Compound 4, half-maximal inhibitory concentration: 20400 nM
Estimate against measurement, compound 4: 4.1-fold (0.61 log units) below, outside the stated range (above it).
By their numbers in this assay, from the lowest: compound 2; then compound 1; then compounds 3 and 4 (each within the scatter of the next).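

In this assay, the exchange of fluoro for methyl gives a 3.6-fold higher number from compound 1 to compound 4 (0.56 log units; beyond the scatter), so this place on the ring responds to a swap of one heavy atom for another with no change in the counted donors or acceptors, something the earlier exchanges of the whole substituent could not show. The 3-methylphenyl group is not separated from the 2-methoxyphenyl group, with a 1.5-fold higher number from compound 3 to compound 4 (0.18 log units; within the scatter), but it stands well apart from the 2,3-dichlorophenyl group, with a 9.3-fold higher number from compound 2 to compound 4 (0.97 log units; beyond the scatter), the widest step in the set so far. Nothing given here accounts for the difference between methyl and fluoro at this position.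

The compounds shown leave open how an amine or a carboxylic acid in this same place would compare with fluoro and methyl. They also leave open whether the step from fluoro to methyl would recur on a ring carrying a further substituent.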